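The source may hold more compounds than are shown below. What is called first, only, known or untested is meant among the compounds shown, and "the series" means these compounds.

Measured so far in a functional assay on HEK293 cells for agonist activity at G-protein coupled receptor 39 (Homo sapiens), read by scintillation proximity assay and inositol phosphate accumulation, with a stated time of 75 min; on this read-out higher numbers stand for an effect only at larger amounts of compound and lower numbers for an effect already at smaller amounts:
compound 1 `Cc1nn(-c2ncnc3nc[nH]c23)c2c1C(c1ccc(OC(C)C)cc1)CC(=O)N2` gives 2700 nM
compound 2 `Cc1nn(-c2ncnc3nc[nH]c23)c2c1C(C(=O)N(C)c1nccs1)CC(=O)N2` gives 3300 nM
compound 3 `Cc1nn(-c2ncnc3nc[nH]c23)c2c1C(C(=O)NCc1ccccc1)CC(=O)N2` gives 2930 nM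

Compound 3 holds the second highest of the three numbers, yet the three are indistinguishable: a 1.1-fold higher number from compound 1 to compound 3 (0.04 log units; within the scatter), a 1.1-fold lower number from compound 2 to compound 3 (0.05 log units; within the scatter), and a 1.2-fold higher number from compound 1 to compound 2 (0.09 log units; within the scatter).

Compound 4 is `Cc1nn(-c2ncnc3nc[nH]c23)c2c1C(C(=O)N(C)c1ccccc1)CC(=O)N2`. Against compound 3 the change is methyl(phenyl)amino in place of benzylamino on a carbonyl carbon. The measured step that bears most directly on it is the exchange at the same carbonyl carbon, methyl(1,3-thiazol-2-yl)amino to benzylamino, where a 1.1-fold lower number from compound 2 to compound 3 (0.05 log units; within the scatter). The larger exchanges at the saturated ring carbon, a 1.2-fold higher number from compound 1 to compound 2 (0.09 log units; within the scatter) and a 1.1-fold higher number from compound 1 to compound 3 (0.04 log units; within the scatter), also left the number where it was. Nothing in these three compounds points in a direction, so no step beyond the scatter is expected in this assay: a 1.0-fold higher number from compound 3 to compound 4 (0.01 log units; within the scatter) is the expected outcome. Compound 4 is therefore estimated at 3000 nM, with an expected range of 1500 nM to 6500 nM.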

Compound 4, half-maximal effective concentration: 5220 nM
Estimate against measurement, compound 4: 1.7-fold (0.24 log units) below; the measured number falls inside the stated range.
By their numbers in this assay, from the lowest: compounds 1, 3, 2 and 4 (each within the scatter of the next).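

In this assay the exchange at the carbonyl carbon, methyl(phenyl)amino in place of benzylamino, takes away the hydrogen-bond donor of benzylamino and gives a 1.8-fold higher number from compound 3 to compound 4 (0.25 log units; within the scatter) in this series. With a 1.6-fold higher number from compound 2 to compound 4 (0.20 log units; within the scatter) for phenyl in place of 1,3-thiazol-2-yl on the amide-type nitrogen and a 1.9-fold higher number from compound 1 to compound 4 (0.29 log units; within the scatter) for methyl(phenyl)carbamoyl in place of 4-isopropoxyphenyl on the saturated ring carbon, the four compounds still show no step beyond the scatter, so neither position yet has a readable preference among these groups. No evidence bearing on these steps is at hand.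

Open, from the compounds shown here alone, is whether the amide hydrogen matters at all: a methyl(benzyl)carbamoyl group would separate it from the link to the phenyl ring. Also open, going by these compounds, is whether a carboxylic acid or a basic amine on the carbamoyl chain would move the number beyond the scatter.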